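The compounds below may be only part of what the source reports. "The series", "measured", "known", "first", "only" and "open" are said of these compounds alone.

Measured compounds: compound 1, `COc1ccccc1N1CCN(CC(=O)C(O)(c2ccccc2)C2CCC2)CC1`; compound 2, `O=C(CN1CCN(Cc2cccs2)CC1)C(O)(c1ccccc1)C1CCC1`; compound 3, `O=C(CN1CCN(C/C=C\c2ccccc2)CC1)C(O)(c1ccccc1)C1CCC1`.

In a functional assay on ileum for antagonist activity at muscarinic acetylcholine receptor M3 (Cavia porcellus) (a lower number here means a stronger inhibitor, a higher number a weaker inhibitor), compound 3 gives 9.92 nM, the lowest number among the measured values. Compound 2 gives 43.8 nM, with a 4.4-fold lower number from compound 2 to compound 3 (0.64 log units; beyond the scatter). For compound 1 the result is a limit of the assay, > 10000 nM, that is the limit of > 10000 nM in this assay, at which 1 of the 3 values shown sits.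

Compound 4, `CCOc1ccccc1N1CCN(CC(=O)C(O)(c2ccccc2)C2CCC2)CC1`, is the next step: 2-ethoxyphenyl in place of 3-phenylprop-2-en-1-yl on an amine nitrogen in a ring. Within the data shown here, the steps that bear on it are those in which an aryl group on the ring nitrogen gave way to a benzylic-type group, an at least 1000-fold lower number from compound 1 to compound 3 (3.00 log units; beyond the scatter) and an at least 220-fold lower number from compound 1 to compound 2 (2.35 log units; beyond the scatter). Compound 4 puts an aryl group of the same kind back on the ring nitrogen, differing from compound 1 only in 2-ethoxyphenyl against 2-methoxyphenyl. A large rise in the number is therefore expected, a 1500-fold higher number from compound 3 to compound 4 (3.18 log units; beyond the scatter), most likely back to a limit. Compound 4 is estimated at 15000 nM, range 3000 nM to 60000 nM.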

Compound 4, antagonist equilibrium constant: > 10000 nM
Compound 4: no number, only a limit (the forecaster's own chance of this, stated with the estimate: 70%); the middle value lies beyond the limit too.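

Compound 4 is a second limit in this assay, not a number: the limit of > 10000 nM in this assay, at which 2 of the 4 values shown sit.

With 2-ethoxyphenyl on the amine nitrogen in the ring, the loss now appears with a second alkoxyphenyl group, as an at least 1000-fold higher number from compound 3 to compound 4 (3.00 log units; beyond the scatter) and an at least 220-fold higher number from compound 2 to compound 4 (2.35 log units; beyond the scatter). The step from compound 1 to compound 4 lies between two limits and cannot be read, so 2-ethoxyphenyl and 2-methoxyphenyl cannot be ordered.

Still open, as far as these compounds go, is whether any aryl group on this nitrogen, such as unsubstituted phenyl or 2-chlorophenyl, gives a number in this assay. Also open, from the compounds shown here alone, is how a saturated 3-phenylpropyl chain compares with 3-phenylprop-2-en-1-yl.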